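Swapping the Aryl Ring for a Nitrogen Ring

A few compounds are considered here, and "the series" means these few. Any claim that something is new, unique, unknown or untested is made for them only; others in the source may bear on it.

Of the compounds shown here, three on a shared core have been measured in an ADME assay on cells (Hepatocyte, Rattus norvegicus) for metabolic stability; a higher number here means faster removal of the compound, a lower number slower removal. Among the measured compounds shown here, compound 1 `CNC(=O)CN1CCC(c2cc3c(-c4ccc(=O)n(C(C)C)c4)ccnc3[nH]2)CC1` gives 8.9 uL/min, and compound 2 `CC(C)n1cc(-c2ccnc3[nH]c(C4CCN(CC(=O)N5CCCC5)CC4)cc23)ccc1=O` gives 5.4 uL/min; the only single-point step among them, a 1.6-fold lower number from compound 1 to compound 2 (0.22 log units; within the scatter), stays within the scatter. Compound 3 `COc1cc(F)ccc1-c1ccnc2[nH]c(C3CCN(CC(=O)N(C)C)CC3)cc12` gives 38 uL/min, the highest of the three, and its distance from both compound 1 and compound 2 lies beyond the scatter. For the measured compounds named here, compound 3 differs from those two in two places, so no single step is drawn for it; the values simply show that it is removed faster.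

Compound 4 `CCn1cc(-c2ccnc3[nH]c(C4CCN(CC(=O)N(C)C)CC4)cc23)ccc1=O` arises from compound 3 by one change: a group of 9 heavy atoms (7 carbon, 1 nitrogen, 1 oxygen; one six-membered aromatic ring with 1 hetero atom) in place of a group of 9 heavy atoms (7 carbon, 1 oxygen, 1 fluorine; one six-membered aromatic ring of carbon only), on an aromatic carbon. The entering ring with one hetero atom closely resembles the ring that compounds 1 and 2 carry in the same position of the shared core, while the dimethylamide of compound 3 is kept. Going by the values given here, the step of a 1.6-fold lower number from compound 1 to compound 2 (0.22 log units; within the scatter) concerns the amide, not this ring, so no measured step bears directly on the change; the values of compounds 1 and 2 are the only guide. Because compound 1 gives 8.9 uL/min and compound 2 gives 5.4 uL/min, a downward step is expected for compound 4, estimated as a 3.8-fold lower number from compound 3 to compound 4 (0.58 log units; beyond the scatter). In this assay compound 4 is expected to give 10 uL/min, with a likely range from 4 uL/min to 25 uL/min.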

Compound 4, intrinsic clearance in a liver preparation (reported as CLH), per the amount of preparation that the assay uses: < 1 uL/min
Compound 4 ended at the assay's limit; the forecaster's own chance of this, stated with the estimate: 5%; at least 10-fold (1.00 log units) between middle value and limit.
By their numbers in this assay, from the lowest: compounds 2 and 1 (each within the scatter of the next); then compound 3. At a limit, below all of these: compound 4.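

In this assay, among the compounds shown here, putting the entering ring with one hetero atom in place of 4-fluoro-2-methoxyphenyl, on this aromatic carbon opposite the ring nitrogen, gives an at least 38-fold lower number from compound 3 to compound 4 (1.57 log units; beyond the scatter), a large step and the first single change here that lies beyond the scatter. For the compounds shown here, the dimethylamide is the same on both sides of this step, which ties the difference to this one position, whereas the only earlier step, a 1.6-fold lower number from compound 1 to compound 2 (0.22 log units; within the scatter), concerned the amide and stayed within the scatter. Compound 4 gives < 1 uL/min, a limit of the assay and not a number, which makes the printed step a minimum: the limit of < 1 uL/min in this assay, at which 1 of the 4 values shown sits.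

The compounds shown leave open which feature of the exchange goes with the large step: the ring nitrogen with its ethyl chain, the ring carbonyl, or the loss of the fluorine or the methoxy from the leaving group. A phenyl ring carrying only the fluorine or only the methoxy at this position, or a propyl chain in place of the ethyl chain, would begin to separate these features.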